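Notes on a sulfonyl substituent change from compound 2

The source may report more compounds than this note shows. Statements on the series, on what has been measured and on what is new or still open speak of the compounds shown alone.

Compound 1 `CC(C)c1noc(N2CCN(C(=O)[C@@H]3CCCN(S(=O)(=O)c4ccc(S(=O)(=O)C(C)C)cc4)C3)CC2)n1`: > 1 h (a limit)
Compound 2 `CC(C)NS(=O)(=O)c1ccc(S(=O)(=O)N2CCC[C@@H](C(=O)N3CCN(c4nc(C(C)C)no4)CC3)C2)cc1`: 0.056 h

Both values come from an ADME assay on microsomes from liver (Homo sapiens) for metabolic stability, read by LC-MS, with a stated time of 60 min, tested at 10 uM; a lower number here means that the compound disappears faster, a higher number that the compound lasts longer. Within the data shown here, compound 2 gives 0.056 h, the only actual number so far. Compound 1 gives > 1 h, which is a limit, and (the limit of > 1 h in this assay, at which 1 of the 2 values shown sits).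

The next structure is compound 3 `CCC(CC)S(=O)(=O)c1ccc(S(=O)(=O)N2CCC[C@@H](C(=O)N3CCN(c4nc(C(C)C)no4)CC3)C2)cc1`, with pentan-3-yl in place of isopropylamino on a sulfonyl sulfur.

Among the measured compounds shown here, one measured step bears on this change: an at least 17-fold lower number from compound 1 to compound 2 (1.25 log units; beyond the scatter). It is large and beyond the scatter, and it put isopropylamino in place of isopropyl on a sulfonyl sulfur. Compound 3 loses that same isopropylamino, so a large move in the opposite direction is expected in this assay, towards a longer half-life. Pentan-3-yl itself has not been measured, however, and compound 1 carries isopropyl instead, so the full return to the level of compound 1 is not assumed.

The expected change is a 7.1-fold higher number from compound 2 to compound 3 (0.85 log units; beyond the scatter). Compound 3 is estimated at 0.4 h, with an expected range from 0.1 h to 1 h.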

Compound 3, half-life: 0.0422 h
The estimate for compound 3 lay 9.5-fold (0.98 log units) above the measured number; the whole stated range lies above it.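

In this assay, putting pentan-3-yl in place of isopropylamino on a sulfonyl sulfur whose other neighbour is an aromatic carbon gives a 1.3-fold lower number from compound 2 to compound 3 (0.12 log units; within the scatter), so losing isopropylamino, and with it a hydrogen-bond donor, does not by itself restore a long half-life. Pentan-3-yl in place of isopropyl at the same place gives an at least 23-fold lower number from compound 1 to compound 3 (1.37 log units; beyond the scatter), which shows that a short half-life at this position is not tied to isopropylamino and that an all-carbon group there does not guarantee a long one. Among the compounds shown, only compound 1 reaches the long end of the scale, and its reading is a limit, not a number, so the true size of both large steps from it stays undefined: the limit of > 1 h in this assay, at which 1 of the 3 values shown sits.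

As far as these compounds go, it remains open whether the long half-life belongs to isopropyl alone or extends to other carbon groups at this sulfur, such as methyl, ethyl or cyclopropyl. Also open, from the compounds shown here alone, is how a dimethylamino group on the same sulfur, which has no hydrogen on its nitrogen, would compare with isopropylamino.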